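The compounds below may be only part of what the source reports. "The series", "measured", "known", "first", "only" and "open" are said of these compounds alone.

Compound 1 `Cc1ccc(S(=O)(=O)/C(=C/c2sccc2C)C(=O)c2ccc(Br)cc2)cc1` is the compound with the highest of the three numbers in a functional assay on DU-145 cells (Homo sapiens) for inhibition, read by trypan blue exclusion, with a stated time of 96 h (on this read-out higher numbers stand for weaker inhibition of growth and lower numbers for stronger inhibition of growth), where compound 1 gives 25000 nM. For the measured compounds named here, its closest neighbour in structure, compound 3 `Cc1ccc(S(=O)(=O)/C(=C/c2sccc2C)C(=O)c2ccc(Cl)cc2)cc1`, gives 10000 nM in this assay, and the step of a 2.5-fold lower number from compound 1 to compound 3 (0.40 log units; beyond the scatter) is the only one-place change among the measured compounds. Going by the values given here, compound 2 `O=C(/C(=C\c1cccc(Cl)c1Cl)SCc1ccc(Cl)cc1)c1ccc(Br)cc1`, built on a different sulfur link and a different aryl group, gives 10000 nM in this assay; no single step connects it to compound 1. Among the compounds with values here, compound 4 `Cc1ccc(S(=O)(=O)/C(=C/c2ccc(N(C)C)cc2)C(=O)c2ccc(Br)cc2)cc1` differs from compound 1 in one place: 4-(dimethylamino)phenyl in place of 3-methylthiophen-2-yl on a double-bonded chain carbon bound to a double-bonded chain carbon None of the measured steps touches the aryl group on the double-bonded chain carbon, so the change from compound 1 to compound 4 has no direct precedent here; the only measured step, a 2.5-fold lower number from compound 1 to compound 3 (0.40 log units; beyond the scatter), concerns the halogen on the aromatic carbon instead. Within the data shown here, with no bearing step, compound 4 is expected to stay close to compound 1, and the step of a 1.3-fold lower number from compound 1 to compound 4 (0.10 log units; within the scatter) is estimated to lie within the scatter. Compound 4 is therefore estimated at 20000 nM, with a range from 5000 nM to 60000 nM.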

Compound 4, concentration for 50% growth inhibition: 50000 nM
Compound 4: middle estimate off by 2.5-fold (0.40 log units), on the low side; the range from low to high includes it.
By their numbers in this assay, from the lowest: compounds 2 and 3 (each within the scatter of the next); then compounds 1 and 4 (each within the scatter of the next).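

In this assay, for the compounds shown here, the exchange at this position, on a double-bonded chain carbon bound to a double-bonded chain carbon, gives a 2.0-fold higher number from compound 1 to compound 4 (0.30 log units; within the scatter), the first measured change to this aryl group. Compound 1 and compound 4 therefore cannot be told apart here, even though a five-membered aromatic ring with 6 heavy atoms gives way to a six-membered aromatic ring of carbon only with 9 heavy atoms. No evidence at hand speaks to what lies behind this result. The compounds shown leave open whether an unsubstituted phenyl, or a phenyl carrying a carboxylic acid in place of the dimethylamino group, would also stay within the scatter of compound 1. They also leave open whether chloro in place of bromo on the aromatic carbon would give a similar step on compound 4.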